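Swapping the triazole substituent: from compound 2 to compound 4

The compounds below may be only part of what the source reports. "The series", "measured", "known", "first", "only" and "open" are said of these compounds alone.

Measured compounds:
- Compound 1, `O=c1nc2oc(CCCCl)c(C#CCCCCCl)c2cn1Cc1cn(-c2ccc(F)cc2)nn1`: 39400 nM
- Compound 2, `O=c1nc2oc(CCCCl)cc2cn1Cc1cn(-c2ccc(F)cc2)nn1`: 68400 nM
- Compound 3, `O=c1nc2oc(C3CC3)c(C#CC3CC3)c2cn1Cc1cn(-c2ccc(Cl)cc2)nn1`: 39000 nM

In a functional assay on A549 cells (Homo sapiens) for antiproliferative activity, read by MTT assay, with a stated time of 72 h (a lower number here means a stronger inhibitor, a higher number a weaker inhibitor), compound 2 gives 68400 nM; this lies within the scatter of compound 1 and compound 3 alike, so the three cannot be told apart. Compound 4, `O=c1nc2oc(CCCCl)cc2cn1Cc1cn(Cc2ccccc2)nn1`, has not been measured. It differs from compound 2 in one spot: benzyl in place of 4-fluorophenyl on an aromatic nitrogen. For the measured compounds named here, the only measured step, a 1.7-fold higher number from compound 1 to compound 2 (0.24 log units; within the scatter), changes a different part of the shared core and stayed within the scatter, so no measured step speaks to this change. With nothing pointing either way, no step beyond the scatter is expected for compound 4: a 1.0-fold higher number from compound 2 to compound 4 (0.01 log units; within the scatter). Compound 4 is therefore estimated at 70000 nM, with a range from 20000 nM to 250000 nM.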

Compound 4, half-maximal inhibitory concentration: 27900 nM
Beside the measured number, compound 4's estimate is 2.5-fold (0.40 log units) above it; the range from low to high includes it.
By their numbers in this assay, from the lowest: compounds 4, 3, 1 and 2 (each within the scatter of the next, the first and the last beyond it).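

For the compounds shown here, this is the first step at the aromatic nitrogen of the five-membered ring, and in this assay it lies beyond the scatter: a 2.5-fold lower number from compound 2 to compound 4 (0.39 log units; beyond the scatter). Going by these compounds alone, the one earlier step, at a different place on the shared core, stayed within the scatter, so this position is the first to show a modest change in the number. No measured evidence accounts for this step.

The swap adds a carbon link and removes the fluorine together, so the two cannot be separated here. As far as these compounds go, how a longer chain such as 2-phenylethyl, or a plain phenyl, would read remains open.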